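Swapping cyclopentyl for methyl on the aromatic oxygen

The source may hold more compounds than are shown below. What is called first, only, known or untested is meant among the compounds shown, and "the series" means these compounds.

Of the compounds shown here, three sharing one core have been measured in a toxicity assay on A549 cells (Homo sapiens) for cytotoxicity, read by luminescence and CellTiter-Glo, with a stated time of 48 h; on this read-out lower numbers stand for higher toxicity in this test and higher numbers for lower toxicity in this test. Compound 1 `O=C(O)CCCOc1ccc(-c2nc3ncccn3c2NC2CCCCC2)cc1` gives > 100000 nM, which is a limit of the assay and not a number. Compound 2 `COCCCCOc1ccc(-c2nc3ncccn3c2NC2CCCCC2)cc1` gives 100000 nM. Compound 3 `c1cnc2nc(-c3ccc(OC4CCCC4)cc3)c(NC3CCCCC3)n2c1` gives 39000 nM, the lowest number of the set, which makes it the most toxic of the three in this test.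

Compound 4 `COc1ccc(-c2nc3ncccn3c2NC2CCCCC2)cc1` is the next to be read, and it differs from compound 3 in one place: methyl in place of cyclopentyl on an oxygen on an aromatic ring. In words, this is methyl in place of cyclopentyl on an oxygen on an aromatic ring.

For the measured compounds named here, two measured steps bear on this change, as both put cyclopentyl on that same oxygen. One is a 2.6-fold lower number from compound 2 to compound 3 (0.41 log units; beyond the scatter), where cyclopentyl replaces 4-methoxybutyl. The other is an at least 2.5-fold lower number from compound 1 to compound 3 (0.40 log units; beyond the scatter), where it replaces 3-carboxypropyl. Both steps are modest in size and both lower the number. Neither starts from methyl, however, so they are only a loose guide.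

Removing the cyclopentyl should partly undo that drop, and a modest rise is expected, a 1.8-fold higher number from compound 3 to compound 4 (0.25 log units; within the scatter). For compound 4 the estimated value is 70000 nM, with an expected range from 30000 nM to 120000 nM.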

Compound 4, half-maximal cytotoxic concentration: > 100000 nM
Compound 4 gave a limit, no number; the forecaster's own chance of this, stated with the estimate: 35%; middle value at least 1.4-fold (0.15 log units) away from the limit.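

In this assay, replacing cyclopentyl with methyl on the aromatic oxygen gives an at least 2.5-fold higher number from compound 3 to compound 4 (0.40 log units; beyond the scatter), so the lower number of compound 3 does not carry over to this much smaller group. Cutting the 4-methoxybutyl chain back to methyl gives a number no lower from compound 2 to compound 4 (the limit leaves the size open), which means that neither the long ether chain nor the short methyl reaches the lower number seen with cyclopentyl. The result for compound 4 is a limit of the assay and not a number, and the true size of these steps stays hidden because the compound sits at the top of the readable range: the limit of > 100000 nM in this assay, at which 2 of the 4 values shown sit.

The steps that involve two limits or leave the size open cannot be read as sizes, so compound 1, compound 2 and compound 4 cannot be ranked against one another. What a cyclohexyl or an isopropyl group would read on that same oxygen remains open, so the compounds shown cannot separate the effect of having a ring there from that of simply carrying more carbon.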